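The source may hold more compounds than are shown below. What is called first, only, known or untested is meant among the compounds shown, and "the series" means these compounds.

Measured in a functional assay on RKO cells (Homo sapiens) for inhibition, read by MTT assay, with a stated time of 48 h; on this read-out lower numbers stand for stronger inhibition and higher numbers for weaker inhibition:
- compound 1 `COc1ccc(N(C)c2nc(C)nc3ccccc23)cc1C(=O)OCC[Se]C#N`: 2390 nM
- compound 2 `Cc1nc(N(C)c2ccc([Se]C#N)c(C)c2)c2ccccc2n1`: 17 nM
- compound 3 `COc1ccc(N(C)c2nc(C)nc3ccccc23)cc1C(=O)OCCC[Se]C#N`: 1140 nM

Compound 2 has the lowest of the three numbers, well under both compound 3 and compound 1. The next compound, compound 4 `Cc1nc(N(C)c2ccc([Se]C#N)c(Cl)c2)c2ccccc2n1`, has not been measured. It differs from compound 2 as follows: chloro in place of methyl on an aromatic carbon. In words, this is chloro in place of methyl on an aromatic carbon, ortho to a group of 3 heavy atoms and meta to a large group.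

Among the measured compounds shown here, the series holds no measured example of this swap, and no other compound carries chloro. For the measured compounds named here, the only measured step, a 2.1-fold lower number from compound 1 to compound 3 (0.32 log units; beyond the scatter), is modest and lies on a saturated chain carbon, so it gives little guidance for a change on an aromatic carbon. The expectation therefore rests on compound 2 at 17 nM, with no shift beyond the scatter anticipated in either direction in this assay. Going by the values given here, the range is kept wide because no direct precedent exists.

The estimated change is a 1.2-fold higher number from compound 2 to compound 4 (0.07 log units; within the scatter).

For compound 4 the expected value is 20 nM, with an estimated range from 7 nM to 60 nM.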

Compound 4, half-maximal inhibitory concentration: 11 nM
The estimate for compound 4 lay 1.8-fold (0.26 log units) above the measured number; the range from low to high includes it.
By their numbers in this assay, from the lowest: compounds 4 and 2 (each within the scatter of the next); then compound 3; then compound 1.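

In this assay, chloro in place of methyl on an aromatic carbon, ortho to a group of 3 heavy atoms and meta to a large group, gives a 1.5-fold lower number from compound 2 to compound 4 (0.19 log units; within the scatter), so the two groups cannot be told apart at this position on this read-out. Among the compounds shown here, this is the first reading of a change on this aromatic carbon, as the earlier step lay on a saturated chain carbon, and it shows that a chlorine atom can replace the methyl carbon while the number stays in the low range set by compound 2 at 17 nM. No measured evidence bears on why the two groups read alike.

The compounds shown leave open how hydrogen, fluoro, methoxy, an amine or a carboxylic acid on this same aromatic carbon would read in this assay, and so how far the latitude seen with methyl and chloro extends. They also leave open whether the same swap would read alike on another cell line, or in a compound carrying the selenocyanate on a longer chain.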